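Notes on the amine substituent: aryl to cyclopentyl

This account rests on a few compounds, and the source may have more. Where it says the series, first, only, none or still open, it means among the compounds named here.

Compound 2 `COc1cccc(NC2=CC(=O)c3c(nc4n3[C@H]3OC[C@@H](O)[C@H]3OC4)C2=O)c1` gives, in a functional assay on ECa-109 cells for inhibition, with ECa-109 cell line (Homo sapiens) as the target, read by sulforhodamine B assay (on this read-out higher numbers stand for weaker inhibition and lower numbers for stronger inhibition), a value of 3340 nM, the higher of the two numbers recorded, with compound 1 `O=C1C=C(Nc2ccc(I)cc2)C(=O)c2c1nc1n2[C@H]2OC[C@@H](O)[C@H]2OC1` close to it within the scatter. In this assay compound 1 gives 2300 nM. Compound 3 `O=C1C=C(NCc2ccccc2)C(=O)c2c1nc1n2[C@H]2OC[C@@H](O)[C@H]2OC1` sits at a limit of the assay, > 8000 nM. The step from compound 2 to compound 4 `O=C1C(NC2CCCC2)=CC(=O)c2c1nc1n2[C@H]2OC[C@@H](O)[C@H]2OC1` is cyclopentyl in place of 3-methoxyphenyl on an amine nitrogen. Within the data shown here, the only measured step bearing on it, an at least 3.4-fold higher number from compound 1 to compound 3 (0.54 log units; beyond the scatter), also took the aromatic ring off the amine nitrogen and moved the value to the limit of > 8000 nM in this assay, at which 1 of the 3 values shown sits. A higher number is therefore expected here, and compound 4 is expected to give 10000 nM (range 4500 nM to 25000 nM), a step of a 3.0-fold higher number from compound 2 to compound 4 (0.48 log units; beyond the scatter), quite possibly reported only as a limit.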

Compound 4, half-maximal inhibitory concentration: > 16000 nM
Compound 4 ended at the assay's limit (the forecaster's own chance of this, stated with the estimate: 55%); at least 1.6-fold (0.20 log units) between middle value and limit.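

Cyclopentyl on the amine nitrogen gives an at least 4.7-fold higher number from compound 2 to compound 4 (0.68 log units; beyond the scatter) and so extends the earlier loss seen with benzyl to a group with no aromatic ring at all. Going by these compounds, for compound 4 the reading is a limit, not a number, so the full size of the step stays unknown: the limit of > 16000 nM in this assay, at which 1 of the 4 values shown sits.

The step changes the aromatic ring and removes the methoxy oxygen together, so the two changes cannot be told apart. Phenyl or cyclohexyl on the same nitrogen would bear on that question.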